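This account rests on a few compounds, and the source may have more. Where it says the series, first, only, none or still open, it means among the compounds named here.

Compound 1 `O=C1c2c[n+]([O-])c3ccccc3c2C(=O)c2c1c1ccccc1n2Cc1cn(C[C@@H](O)CO)nn1` is one of three congeners that share a core and differ only in the group on the nitrogen of that core. In a functional assay on A-375 cells (Homo sapiens) for cytotoxicity, read by MTT assay, with a stated time of 72 h (on this read-out higher numbers stand for weaker inhibition and lower numbers for stronger inhibition), compound 1 gives 140 nM, the second highest of the three numbers. Compound 2 `CC1(C)OCC(Cn2cc(Cn3c4c(c5ccccc53)C(=O)c3c[n+]([O-])c5ccccc5c3C4=O)nn2)O1` gives 330 nM in this assay, and the step is a 2.4-fold higher number from compound 1 to compound 2 (0.37 log units; beyond the scatter). Compound 3 `O=C1c2c[n+]([O-])c3ccccc3c2C(=O)c2c1c1ccccc1n2Cc1cn([C@@H]2C[C@H](O)[C@@H](CO)O2)nn1` gives 20 nM, and the step is a 7.0-fold lower number from compound 1 to compound 3 (0.85 log units; beyond the scatter); between the other pair it is a 17-fold lower number from compound 2 to compound 3 (1.22 log units; beyond the scatter).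

Compound 4 `CCCN1CCN(CCCCn2c3c(c4ccccc42)C(=O)c2c[n+]([O-])c4ccccc4c2C3=O)CC1` differs from compound 1 as follows: 3-(4-propylpiperazin-1-yl)propyl in place of 1-(2,3-dihydroxypropyl)-1H-1,2,3-triazol-4-yl on a saturated chain carbon bound to an aromatic nitrogen. None of the three measured steps covers this change, since all of them keep the triazole and vary only the group on it; they show only that altering what sits on the saturated chain carbon bound to the aromatic nitrogen shifts the number by modest to large amounts in either direction. Among the measured compounds shown here, the 1,2-dihydroxyethyl group of compound 1 is lost here, and the one measured step that removed free hydroxyls, a 2.4-fold higher number from compound 1 to compound 2 (0.37 log units; beyond the scatter), gave a higher number, so a modest rise is expected. Compound 4 is therefore expected at 300 nM in this assay, with a range from 60 nM to 1500 nM, a step of a 2.1-fold higher number from compound 1 to compound 4 (0.33 log units; beyond the scatter).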

Compound 4, half-maximal inhibitory concentration: 870 nM
Compound 4: the middle estimate sits 2.9-fold (0.46 log units) below what was measured; the measured number falls inside the stated range.
By their numbers in this assay, from the lowest: compound 3; then compound 1; then compound 2; then compound 4.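

In this assay, the step from the triazole series to a chain without a triazole gives a 6.2-fold higher number from compound 1 to compound 4 (0.79 log units; beyond the scatter), so 3-(4-propylpiperazin-1-yl)propyl on a saturated chain carbon bound to an aromatic nitrogen gives a higher number than 1-(2,3-dihydroxypropyl)-1H-1,2,3-triazol-4-yl, although compound 4 still reads 870 nM. The earlier compounds shown here changed only what sits on the triazole, whereas here the five-membered aromatic ring and both hydroxyl groups leave together and a six-membered non-aromatic ring with 2 hetero atoms enters, so this single step cannot be divided among those parts. No measurement given here accounts for the size of this rise.

The compounds shown leave open whether the rise follows the loss of the triazole or the arrival of the piperazine, which a triazole carrying a 4-propylpiperazin-1-yl group on its chain would help to separate. They also leave open how a plain butyl chain on the aromatic nitrogen, or a chain ending in a primary amine, would read against compound 1 and compound 4.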